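Phenyl Carbamate Replaces Isobutyl in a Selenocyanate Series

This account rests on a few compounds, and the source may have more. Where it says the series, first, only, none or still open, it means among the compounds named here.

Compound 1 `CC(C)COC(=O)Nc1ccc([Se]C#N)cc1` and compound 2 `O=C(Nc1ccc([Se][Se]c2ccc(NC(=O)OCc3ccc([N+](=O)[O-])cc3)cc2)cc1)OCc1ccc([N+](=O)[O-])cc1` were both tested in a functional assay on CCRF-CEM cells (Homo sapiens) for cytotoxicity, read by MTT assay, with a stated time of 72 h; a lower number here means a stronger inhibitor of growth, a higher number a weaker inhibitor of growth. In this assay compound 1 gives 38300 nM, the higher of the two numbers shown, while compound 2 gives 36500 nM, a gap that lies within the scatter. Compound 3 `N#C[Se]c1ccc(NC(=O)Oc2ccccc2)cc1` carries phenyl in place of isobutyl on an oxygen next to a carbonyl group relative to compound 1. Among the measured compounds shown here, no measured pair shows this change, so its size cannot be read from the data. A step of no more than the scatter, in either direction, is expected: a 1.2-fold lower number from compound 1 to compound 3 (0.08 log units; within the scatter). Compound 3 is therefore estimated at 32000 nM, with a range from 11000 nM to 95000 nM.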

Compound 3, concentration for total growth inhibition: 48000 nM
Beside the measured number, compound 3's estimate is 1.5-fold (0.18 log units) below it, and the stated range covers the measured number.
By their numbers in this assay, from the lowest: compounds 2, 1 and 3 (each within the scatter of the next).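

In this assay, among the compounds shown here, phenyl in place of isobutyl on an oxygen next to a carbonyl group gives a 1.3-fold higher number from compound 1 to compound 3 (0.10 log units; within the scatter), the first measured step at this position. At this place, therefore, the assay does not separate phenyl from isobutyl, although the two groups differ in size and only phenyl has a ring. No accompanying measurement bears on this step. Going by these compounds, whether a longer chain in place of isobutyl, or an amine or a carboxylic acid on the phenyl ring, would move the number beyond the scatter remains open.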